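The source may report more compounds than this note shows. Statements on the series, on what has been measured and on what is new or still open speak of the compounds shown alone.

In a functional assay on DU-145 cells (Homo sapiens) for cytotoxicity, read by ELISA, with a stated time of 4 days (on this read-out lower numbers stand for stronger inhibition and higher numbers for weaker inhibition), three compounds give values that cannot be told apart: compound 1 `Cc1ccc(-c2cc(-c3ccoc3)cc(-c3ccc(Cl)s3)n2)o1` gives 33400 nM, compound 2 `Cc1ccc(-c2cc(-c3ccoc3)cc(-c3ccc(Cl)s3)n2)cc1` gives 25300 nM and compound 3 `Clc1ccc(-c2cc(-c3ccoc3)cc(-c3ccc(Cl)s3)n2)cc1` gives 29500 nM. Compound 3 therefore stands within the scatter of both others. Compound 4 `Clc1ccc(-c2cc(-c3ccoc3)cc(-c3cccnc3)n2)s1` carries pyridin-3-yl in place of 4-chlorophenyl on an aromatic carbon, next to the ring nitrogen (pyridin-3-yl in place of 4-chlorophenyl on an aromatic carbon). The measured changes at this place are a 1.3-fold lower number from compound 1 to compound 2 (0.12 log units; within the scatter), a 1.1-fold lower number from compound 1 to compound 3 (0.05 log units; within the scatter) and a 1.2-fold higher number from compound 2 to compound 3 (0.07 log units; within the scatter), and all stay within the scatter. None of them puts pyridin-3-yl there, so the evidence is indirect. The expected change is small, no larger than the scatter, and is estimated as a 1.2-fold lower number from compound 3 to compound 4 (0.07 log units; within the scatter). For compound 4 the estimated value is 25000 nM, with an expected range from 10000 nM to 55000 nM.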

Compound 4, half-maximal inhibitory concentration: 18500 nM
For compound 4 the middle estimate is 1.4-fold (0.13 log units) above the measured one; low and high end bracket the measured number.
By their numbers in this assay, from the lowest: compounds 4, 2, 3 and 1 (each within the scatter of the next).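

Pyridin-3-yl, with its ring nitrogen, changes little at this place in this assay: the shift is a 1.6-fold lower number from compound 3 to compound 4 (0.20 log units; within the scatter) and a 1.4-fold lower number from compound 2 to compound 4 (0.14 log units; within the scatter) and a 1.8-fold lower number from compound 1 to compound 4 (0.26 log units; within the scatter). A six-membered aromatic ring with a hetero atom therefore fits here as well as the carbon-only rings and 5-methylfuran-2-yl, with no difference that rises above the scatter. Nothing available bears on the reason for this. Going by these compounds, what an amine, a carboxylic acid or a longer chain would do at this place stays open, as does whether any group here can move the number beyond the scatter.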